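The source may report more compounds than this note shows. Statements on the series, on what has been measured and on what is new or still open speak of the compounds shown alone.

In a functional assay on Ehrlich cells (Mus musculus) for cytotoxicity, read by LDH release, with a stated time of 48 h (on this read-out higher numbers stand for weaker inhibition and lower numbers for stronger inhibition), compound 1 `Cc1ccc(OCC(=O)NNC(=O)c2cc3ccccc3oc2=O)c(C(=O)c2cccc(Cl)c2)c1` gives 65400 nM and compound 2 `Cc1ccc(OCC(=O)NNC(=O)c2cc3ccccc3oc2=O)c(C(=O)c2ccccc2Cl)c1` gives 47600 nM. These two values lie within the scatter of each other, so compound 2 stands level with compound 1 and the pair cannot be ranked. Compound 3 `Cc1ccc(OCC(=O)NNC(=O)c2cc3ccccc3oc2=O)c(C(=O)c2ccc(Br)cc2)c1` keeps the shared core and carries one change, 4-bromophenyl in place of 2-chlorophenyl on a carbonyl carbon. Among the compounds with values here, the only measured step that bears on this is a 1.4-fold lower number from compound 1 to compound 2 (0.14 log units; within the scatter), a swap of 3-chlorophenyl for 2-chlorophenyl at the same place. Within the data shown here, no measured compound carries 4-bromophenyl, so this evidence is indirect and thin. No step beyond the scatter is therefore expected in this assay, and no direction can be favoured. The expected step is small: a 1.1-fold higher number from compound 2 to compound 3 (0.02 log units; within the scatter). The estimated value for compound 3 is 50000 nM, with an expected range of 24000 nM to 105000 nM.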

Compound 3, half-maximal inhibitory concentration: 89000 nM
Compound 3: middle estimate off by 1.8-fold (0.25 log units), on the low side; low and high end bracket the measured number.
By their numbers in this assay, from the lowest: compounds 2, 1 and 3 (each within the scatter of the next).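

In this assay the new group on the carbonyl carbon gives two steps (a 1.9-fold higher number from compound 2 to compound 3 (0.27 log units; within the scatter) and a 1.4-fold higher number from compound 1 to compound 3 (0.13 log units; within the scatter)) and both stay within the scatter, so compounds 1, 2 and 3 stand level and cannot be ranked. Within the data shown here, the earlier pair compared only two chlorophenyl groups, whereas compound 3 shows that 4-bromophenyl, which differs in both the halogen and its place on the ring, also produces no step beyond the scatter. Nothing available here explains these numbers.

Because the halogen and its ring place change together in compound 3, the contribution of each cannot be separated, and 4-chlorophenyl would be needed to pull them apart. From the compounds shown here alone, it also remains open whether a plain phenyl, or a phenyl carrying an amine or a carboxylic acid, would produce a step beyond the scatter at this place.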